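The source may hold more compounds than are shown below. What is called first, only, known or untested is meant among the compounds shown, and "the series" means these compounds.

Measured in a functional assay on HCT-116 cells (Homo sapiens) for inhibition, read by CCK-8 assay, with a stated time of 48 h (a lower number here means a stronger inhibitor, a higher number a weaker inhibitor), so far
compound 1 `COc1ccc(CN(C(=O)CSC(=S)N2CCN(C)CC2)c2cc(OC)c(OC)c(OC)c2)cc1` gives 2640 nM
compound 2 `COc1ccc(CN(C(=O)CN2CCN(C(C)=O)CC2)c2cc(OC)c(OC)c(OC)c2)cc1` gives > 20000 nM as a limit of the assay
compound 3 `COc1ccc(CN(C(=O)CSC(=S)N2CCN(C(=O)OC(C)(C)C)CC2)c2cc(OC)c(OC)c(OC)c2)cc1F` gives 8210 nM

Compound 3 at 8210 nM has a higher number than compound 1 at 2640 nM and so is the weaker inhibitor of that pair. Compound 4 `COc1ccc(CN(C(=O)CSC(=S)N2CCN(C(=O)OC(C)(C)C)CC2)c2cc(OC)c(OC)c(OC)c2)cc1O` carries hydroxy in place of fluoro on an aromatic carbon, ortho to a methoxy group hydroxy in place of fluoro on an aromatic carbon in the change from 3-fluoro-4-methoxybenzyl to 3-hydroxy-4-methoxybenzyl. Among the measured compounds shown here, the only measured step is an at least 7.5-fold higher number from compound 1 to compound 2 (0.87 log units; beyond the scatter) and it falls on a saturated chain carbon bound to a carbonyl carbon, so no measured step bears directly on this aromatic carbon. The expectation therefore stays close to compound 3 at 8210 nM with no shift beyond the scatter expected in this assay for now. The estimated change is a 1.4-fold lower number from compound 3 to compound 4 (0.14 log units; within the scatter) and it remains uncertain. Compound 4 is expected at 6000 nM with an estimated range of 1500 nM to 20000 nM in this assay.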

Compound 4, half-maximal inhibitory concentration: 128 nM
Compound 4: middle estimate off by 47-fold (1.67 log units), on the high side; the whole stated range lies above it.
By their numbers in this assay, from the lowest: compound 4; then compound 1; then compound 3. At a limit, above all of these: compound 2.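

In this assay, replacing fluoro with hydroxy on this aromatic carbon, ortho to a methoxy group, gives a 64-fold lower number from compound 3 to compound 4 (1.81 log units; beyond the scatter). Among the compounds shown here, this shows that the group at this position can strongly change the result, which the earlier compounds, with no step here, could not show. The change adds a hydrogen-bond donor and a hydrogen-bond acceptor by count, but nothing shown explains the step. On these data alone, it remains open how an amine or a methoxy group at this carbon would compare with hydroxy. Also open, as far as these compounds go, is whether the 3-hydroxy-4-methoxybenzyl group would give a similar step on the core of compound 1.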